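The source may report more compounds than this note shows. Statements on the series, on what has been measured and on what is new or still open speak of the compounds shown alone.

In an ADME assay on microsomes from liver (Mus musculus) for metabolic stability, with a stated time of 10 min (a higher number here means that more of the compound is left, a lower number that less of the compound is left), compound 1 (`Cc1cccc(F)c1COC(c1ccc([C@]2(S(=O)(=O)c3ccc(F)cc3)CCN(C(=O)[C@H]3CC[C@H](C(=O)O)CC3)C2)cc1)(C(F)(F)F)C(F)(F)F`) gives 78% while compound 2 (`O=C(O)[C@H]1CC[C@H](C(=O)N2CC[C@](c3ccc(C(OCc4c(F)cccc4Cl)(C(F)(F)F)C(F)(F)F)cc3)(S(=O)(=O)c3ccc(F)cc3)C2)CC1`) gives 87% and compound 3 (`COc1cccc(F)c1COC(c1ccc([C@]2(S(=O)(=O)c3ccc(F)cc3)CCN(C(=O)[C@H]3CC[C@H](C(=O)O)CC3)C2)cc1)(C(F)(F)F)C(F)(F)F`) gives 88% there. Compound 3 therefore stands within the scatter of both other compounds. The change to compound 4 (`O=C(O)[C@H]1CC[C@H](C(=O)N2CC[C@](c3ccc(C(OCC4CC4)(C(F)(F)F)C(F)(F)F)cc3)(S(=O)(=O)c3ccc(F)cc3)C2)CC1`) is larger (cyclopropyl in place of 2-fluoro-6-methoxyphenyl on a saturated chain carbon bound to an oxygen on a saturated carbon). The measured steps (a number 9 percentage points higher from compound 1 to compound 2 (within the scatter) and a number 10 percentage points higher from compound 1 to compound 3 (within the scatter) and a number 1 percentage points higher from compound 2 to compound 3 (within the scatter)) each only exchange one group on an aromatic carbon. None of them replaces the whole 2-fluoro-6-methoxyphenyl, so they bear on this change only loosely and the uncertainty is wide. Only a small downward step is expected (a number 8 percentage points lower from compound 3 to compound 4 (within the scatter)). The value expected in this assay for compound 4 is 80% (range 60% to 93%).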

Compound 4, percent of the compound remaining: 44%
Compound 4: the middle estimate sits 36 percentage points above what was measured; the measured number lies below the stated range.
By their numbers in this assay, from the lowest: compound 4; then compounds 1, 2 and 3 (each within the scatter of the next).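

At this place, on a saturated chain carbon bound to an oxygen on a saturated carbon, the whole group carries far more weight in this assay than the exchanges on the aromatic ring did. Cyclopropyl gives a large drop against each substituted phenyl (a number 44 percentage points lower from compound 3 to compound 4 (beyond the scatter)) (a number 43 percentage points lower from compound 2 to compound 4 (beyond the scatter)) (a number 34 percentage points lower from compound 1 to compound 4 (beyond the scatter)). Nothing available explains this drop.

The compounds shown leave open whether the aromatic ring or simply the size of the group counts. A cyclohexyl or an unsubstituted phenyl at this place would help to separate the two.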